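The source may report more compounds than this note shows. Statements on the series, on what has been measured and on what is new or still open speak of the compounds shown alone.

Compound 1 `Brc1cccc(Br)c1N(CC1CC1)C1=NCCN1` stands lowest of the three compounds in a physicochemical assay for lipophilicity (on this read-out lower numbers stand for lower lipophilicity and higher numbers for higher lipophilicity), where compound 1 gives -1.12. Compound 2 `CCN(C1=NCCN1)c1c(Br)cccc1Br` gives -1.01, and compound 3 `Brc1cccc(Br)c1N(CC1CCC1)C1=NCCN1` gives -0.06. The step of a number 0.11 log units higher from compound 1 to compound 2 (within the scatter) lies within the scatter, whereas a number 1.06 log units higher from compound 1 to compound 3 (beyond the scatter) and a number 0.95 log units higher from compound 2 to compound 3 (beyond the scatter) both lie beyond it. Compound 4 `Brc1cccc(Br)c1N(CC1CCCCC1)C1=NCCN1` differs from compound 1 in one place: cyclohexyl in place of cyclopropyl on a saturated chain carbon bound to a nitrogen on an aromatic ring. The step from cyclopropyl to cyclobutyl bears most directly on this change, and it was large, so a step in the same direction and of at least that size is expected: a number 2.02 log units higher from compound 1 to compound 4 (beyond the scatter). In this assay compound 4 is therefore estimated at 0.9, with a range from 0.3 to 1.5.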

Compound 4, distribution coefficient: 0.27
The estimate for compound 4 lay 0.63 log units above the measured number, outside the stated range (below it).
By their numbers in this assay, from the lowest: compounds 1 and 2 (each within the scatter of the next); then compound 3; then compound 4.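

In this assay, cyclohexyl at this place still gives a higher number, with a number 1.39 log units higher from compound 1 to compound 4 (beyond the scatter) and a number 1.28 log units higher from compound 2 to compound 4 (beyond the scatter). The further move from cyclobutyl adds only a number 0.33 log units higher from compound 3 to compound 4 (beyond the scatter), against a number 1.06 log units higher from compound 1 to compound 3 (beyond the scatter) for the move from cyclopropyl to cyclobutyl, so among these rings most of the rise is already reached at cyclobutyl. Nothing in the material shown accounts for this uneven rise. As far as these compounds go, whether cycloheptyl would extend the rise remains open, as does what a longer open chain, an amine or a carboxylic acid would do at this place.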